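Aryl Ureas on Oryza sativa: Bromo Replacing Ethoxycarbonyl

The source may hold more compounds than are shown below. What is called first, only, known or untested is meant among the compounds shown, and "the series" means these compounds.

Three compounds have been measured in an ADME assay on the whole organism with Oryza sativa as the target, tested at 0.1 uM; a lower number here means a stronger effect, a higher number a weaker effect of the compound at the concentration tested:

compound 1, `CCCc1ccc(NC(=O)N[C@@H](C)c2ccccc2)cc1`, gives 97%
compound 2, `C[C@H](NC(=O)Nc1ccc(C(C)(C)C)cc1)c1ccccc1`, gives 100%
compound 3, `CCOC(=O)c1ccc(NC(=O)N[C@@H](C)c2ccccc2)cc1`, gives 99%

All three share one urea core and differ only in the group on one aromatic carbon. Compound 3 sits second highest of the three numbers, and none of the three differs from another beyond the scatter: a number 3 percentage points higher from compound 1 to compound 2 (within the scatter), a number 2 percentage points higher from compound 1 to compound 3 (within the scatter) and a number 1 percentage points lower from compound 2 to compound 3 (within the scatter).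

The next compound, compound 4, is `C[C@H](NC(=O)Nc1ccc(Br)cc1)c1ccccc1`. It differs from compound 3 in one place: bromo in place of ethoxycarbonyl on an aromatic carbon. Within the data shown here, no measured step introduces a bromo group, so the bearing of the earlier steps is only indirect: each of them exchanged one group on that same aromatic carbon and produced a change within the scatter. Three exchanges at one position without effect beyond the scatter give no ground to expect anything else for a fourth, so no step beyond the scatter is expected in this assay for compound 4, as expressed by a number 1 percentage points lower from compound 3 to compound 4 (within the scatter).

Compound 4 is therefore estimated at 98% in this assay, within a range from 90% to 102%.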

Compound 4, a percentage reported as activity, at one concentration (the size of the read-out at that concentration, not a potency): 98%
The estimate for compound 4 equals the measured number at the digits printed; the measured number falls inside the stated range.
By their numbers in this assay, from the lowest: compounds 1, 4, 3 and 2 (each within the scatter of the next).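

In this assay, bromo in place of ethoxycarbonyl gives a number 1 percentage points lower from compound 3 to compound 4 (within the scatter) and so shows that this aromatic carbon, para to a large group, tolerates the exchange of a group of 5 heavy atoms with 2 hydrogen-bond acceptors for a single bromine atom with none, without a step beyond the scatter. Among these compounds, the exchanges against the two remaining groups read alike, with bromo in place of tert-butyl giving a number 2 percentage points lower from compound 2 to compound 4 (within the scatter) and bromo in place of propyl giving a number 1 percentage points higher from compound 1 to compound 4 (within the scatter) and thereby extending the set of groups at this position to four, now including a halogen, with no pair of compounds separated beyond the scatter. No supporting evidence is available that would account for this result.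

On these data alone, whether an amine, a carboxylic acid or a longer chain on this same carbon would produce a step beyond the scatter remains open. Also open, as far as these compounds go, is whether a change elsewhere in the shared core, such as on the unsubstituted phenyl group or at the urea, would move the number in this assay at all.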